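This account rests on a few compounds, and the source may have more. Where it says the series, first, only, none or still open, it means among the compounds named here.

In an ADME assay (liver) for metabolic stability, with Liver microsome (Homo sapiens) as the target, read by LC-MS, using microsomes, with a stated time of 30 min, tested at 4 uM (a lower number here means that less of the compound is left, a higher number that more of the compound is left), compound 3 (`Cc1nc(N2CCN(C)CC2)c2nc(-c3cccc(C(F)(F)F)c3)n(C3CCOCC3)c2n1`) stands lowest of the three measured compounds at 19%. Compound 2 (`COCCn1c(-c2ccccc2Cl)nc2c(N3CCN4C(=O)CCC4C3)nc(C)nc21`) gives 32% and compound 1 (`COCCn1c(-c2ccccc2Cl)nc2c(N3CCN(C(C)=O)CC3)nc(C)nc21`) gives 35%. The gap from compound 3 to each of these two lies beyond the scatter. Compound 4 (`COc1ccc(-c2nc3c(N4CCN(C)CC4)nc(C)nc3n2C2CCOCC2)c(C)c1`) carries 4-methoxy-2-methylphenyl in place of 3-(trifluoromethyl)phenyl on an aromatic carbon. Among the compounds with values here, the only measured step, a number 3 percentage points lower from compound 1 to compound 2 (within the scatter), lies within the scatter, but it concerns a different place in the structure, so no measured step covers this change. With no such evidence, no shift beyond the scatter is expected in this assay. The expected step is a number 1 percentage points lower from compound 3 to compound 4 (within the scatter). For compound 4 the estimated value is 18%, with an expected range of 6% to 36%.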

Compound 4, percent of the compound remaining: 21%
Estimate against measurement, compound 4: 3 percentage points below; measured number inside the range.
By their numbers in this assay, from the lowest: compounds 3 and 4 (each within the scatter of the next); then compounds 2 and 1 (each within the scatter of the next).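

In this assay, the swap of 3-(trifluoromethyl)phenyl for 4-methoxy-2-methylphenyl on this aromatic carbon gives a number 2 percentage points higher from compound 3 to compound 4 (within the scatter). Within the data shown here, this is the first reading at this position, and two quite differently substituted phenyl groups show no difference here. Nothing available bears on what lies behind this result.

Going by these compounds, it remains open whether a phenyl ring carrying a carboxylic acid, or a pyridine ring, at this position would shift the number beyond the scatter. The same question stands for an amine in place of the oxan-4-yl group.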